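Butylamino replacing dimethylamino on the shared core

This account rests on a few compounds, and the source may have more. Where it says the series, first, only, none or still open, it means among the compounds named here.

Compound 1 `CN(C)c1nc(N)nc2c1ncn2/C=C1/CC1(CO)CO` carries a dimethylamino group on the shared core. In an ADME assay on MOLT-3 cells (Homo sapiens) for cytotoxicity, with a stated time of 7 days (on this read-out higher numbers stand for lower toxicity in this test and lower numbers for higher toxicity in this test), compound 1 gives "not determined" (no result reported), so no single number places it on the scale. Compound 2 `CCCCOc1nc(N)nc2c1ncn2/C=C1/CC1(CO)CO` carries a butoxy group at the same site. In this assay compound 2 reaches only a limit, > 20000 nM, and no number is known. Among the values at hand, the limit of > 20000 nM in this assay, at which 1 of the 2 values shown sits, is the only quantitative anchor for the series. Compound 3 `CCCCNc1nc(N)nc2c1ncn2/C=C1/CC1(CO)CO` is still to be measured in this assay. The change from compound 1 to compound 3 is butylamino in place of dimethylamino on an aromatic carbon. Among the measured compounds shown here, no measured step between compounds is available, so the size of the step for compound 3 in this assay cannot be taken from a neighbouring pair; a shift beyond the usual scatter in either direction is not expected from what is known. For compound 3 in this assay the estimate is 30000 nM, with a range from 8000 nM to 100000 nM, the result expected to sit near the limit.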

Compound 3, half-maximal cytotoxic concentration: > 20000 nM
Compound 3: only a limit was reported; the forecaster's own chance of this, stated with the estimate: 70%; the middle value does not contradict the limit.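

In this assay, among the compounds shown here, compound 2 and compound 3 each give only a limit, and no step between them can be read. The compounds shown leave open where any of compounds 1, 2 and 3 falls on the scale of this assay, and whether dimethylamino, butoxy and butylamino differ there at all.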